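Trifluoromethyl for fluoro on the aryl of a dioxepane peroxide

This account rests on a few compounds, and the source may have more. Where it says the series, first, only, none or still open, it means among the compounds named here.

Measured compounds:
compound 1, `CCOC(=O)CC1CCC2(CC1)OOCCCOO2`: 2.2
compound 2, `c1ccc(CC2CCC3(CC2)OOCCCOO3)cc1`: 3.93
compound 3, `Fc1ccc(CC2CCC3(CC2)OOCCCOO3)cc1`: 4.01

Of the compounds shown here, three sharing one saturated peroxide core have been measured in a physicochemical assay for lipophilicity; on this read-out lower numbers stand for lower lipophilicity and higher numbers for higher lipophilicity. Compound 1 carries an ethoxycarbonyl on its side chain and gives 2.2; compound 2 carries a phenyl there and gives 3.93; compound 3 carries a 4-fluorophenyl and gives 4.01. The steps of a number 1.73 log units higher from compound 1 to compound 2 (beyond the scatter) and a number 1.81 log units higher from compound 1 to compound 3 (beyond the scatter) are both large, while a number 0.08 log units higher from compound 2 to compound 3 (within the scatter) lies within the scatter, so compound 3 and compound 2 cannot be told apart on this assay, and compound 1 sits well below both.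

Compound 4, `FC(F)(F)c1ccc(CC2CCC3(CC2)OOCCCOO3)cc1`, is not yet measured. It differs from compound 3 as follows: trifluoromethyl in place of fluoro on an aromatic carbon. Among the measured compounds shown here, the only measured step on that aromatic carbon is a number 0.08 log units higher from compound 2 to compound 3 (within the scatter), a change of one heavy atom; no step in this set exchanges a fluoro for a trifluoromethyl, which brings in four heavy atoms. The account therefore rests on the direction seen, not on a measured size. For compound 4 a step of a number 0.74 log units higher from compound 3 to compound 4 (beyond the scatter) is expected, rising beyond the scatter. Compound 4 is estimated at 4.75, with a range from 4.4 to 5.1.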

Compound 4, partition coefficient: 4.79
Estimate against measurement, compound 4: 0.04 log units below, and the stated range covers the measured number.
By their numbers in this assay, from the lowest: compound 1; then compounds 2 and 3 (each within the scatter of the next); then compound 4.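

On the aromatic carbon para to a large group, this assay now resolves a change, which the fluoro for hydrogen exchange did not do: trifluoromethyl in place of fluoro gives (a number 0.78 log units higher from compound 3 to compound 4 (beyond the scatter)), and trifluoromethyl in place of hydrogen gives (a number 0.86 log units higher from compound 2 to compound 4 (beyond the scatter)). Both steps are modest and beyond the scatter, so compound 4 stands clear of compound 2 and compound 3, which themselves remain within the scatter of each other. The position therefore does respond on this read-out, but only to the larger of the two groups seen there.

Nothing at hand gives a cause for this rise. On these data alone, what a nitrile, a methoxy group or a longer chain would do on the same aromatic carbon remains open, so these compounds fix no trend for the position.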